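The source may hold more compounds than are shown below. What is called first, only, known or untested is meant among the compounds shown, and "the series" means these compounds.

Measured compounds:
compound 1, `C[C@H](NC(=O)Nc1ccccc1F)c1ccccc1`, 98%;
compound 2, `C[C@H](NC(=O)Nc1cccc(F)c1)c1ccccc1`, 97%;
compound 3, `C[C@@H](NC(=O)Nc1cccc(F)c1F)c1ccccc1`, 100%.

In an ADME assay on the whole organism with Oryza sativa as the target, tested at 0.1 uM (a higher number here means a weaker effect of the compound at the concentration tested, a lower number a stronger effect), compound 3 gives the highest of the three numbers, yet it stands within the scatter of compound 1, which gives 98%, and of compound 2, which gives 97%, so no order among the three can be read from these values. Compound 4, `C[C@H](NC(=O)Nc1cccc(F)c1F)c1ccccc1`, has not yet been tested. The change from compound 3 is described thus: the two compounds have the same atoms and bonds and differ only in configuration as drawn: 1 of 1 stereo elements differ; a stereocentre at a saturated chain carbon is drawn R in compound 3 and S in compound 4. Within the data shown here, no step between two measured compounds of this kind is known here. Since all three measured values lie within the scatter of one another, a step of a number 3 percentage points lower from compound 3 to compound 4 (within the scatter) that stays within the scatter is expected. Compound 4 is estimated to give 97%, between 86% and 100%.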

Compound 4, a percentage reported as activity, at one concentration (the size of the read-out at that concentration, not a potency): 100%
Compound 4: the middle estimate sits 3 percentage points below what was measured; the measured number falls inside the stated range.
By their numbers in this assay, from the lowest: compounds 2, 1, 3 and 4 (each within the scatter of the next).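

In this assay, turning the stereocentre at the saturated chain carbon from R to S gives no change at the digits printed from compound 3 to compound 4 (within the scatter), so neither drawn configuration stands apart at this centre. Fluoro in place of hydrogen on an aromatic carbon gives a number 3 percentage points higher from compound 2 to compound 4 (within the scatter) and a number 2 percentage points higher from compound 1 to compound 4 (within the scatter), so neither of these replacements moves the number beyond the scatter. The first of these steps isolates a single structural point: the fact that compounds 3 and 4 differ only in the configuration as drawn

On these data alone, whether a chloro or methoxy group in place of fluoro, or a carboxylic acid on the shared core, would move the number in this assay beyond the scatter stays open.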